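Rearranging a Carbamate Side Chain on an Aziridinylquinone Core

The source may hold more compounds than are shown below. What is called first, only, known or untested is meant among the compounds shown, and "the series" means these compounds.

Measured compounds:
Compound 1, `CC1=C(N2CC2)C(=O)C(CC(C)OC(N)=O)=C(N2CC2)C1=O`, 6.14
Compound 2, `CN(C)C(=O)OCCC1=C(N2CC2)C(=O)C(CCOC(=O)N(C)C)=C(N2CC2)C1=O`, 5.16
Compound 3, `CCCC1=C(N2CC2)C(=O)C(CCC)=C(N2CC2)C1=O`, 4.92

Three compounds that share a bis(aziridinyl)quinone core have been tested in a functional assay on L1210 cells (Mus musculus), with a stated time of 12 days; a lower number here means a less potent compound, a higher number a more potent compound, by a factor of ten per unit of this negative logarithm. Compound 1 gives 6.14, the highest of the three numbers. Compound 2 stands closest to it, with a lower number, which is beyond the scatter of this assay. Compound 3 stands furthest, with a number lower still, also beyond the scatter. Compound 1 can therefore be called the most potent of the three in this assay.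

The unmeasured compound 4, `CC1=C(N2CC2)C(=O)C(C(C)COC(N)=O)=C(N2CC2)C1=O`, is built from the same atoms as compound 1, joined differently. The difference is a group of 7 heavy atoms (4 carbon, 1 nitrogen, 2 oxygen; no ring) in place of a group of 7 heavy atoms (4 carbon, 1 nitrogen, 2 oxygen; no ring), on a double-bonded ring carbon. Both side chains carry a carbamate of equal size and the same count of donors and acceptors; only the branching of the chain is rearranged.

Within the data shown here, no step between two measured compounds isolates such a rearrangement, so the expected size of the step in this assay from compound 1 to compound 4 is small, with no direction favoured and quite possibly within the scatter. Compound 4 is estimated at 6, within 5.5 to 6.5, a step of a number 0.14 log units lower from compound 1 to compound 4 (within the scatter) that is expected to stay near compound 1.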

Compound 4, logarithm of the reciprocal of the active concentration, log(1/C): 6.41
Beside the measured number, compound 4's estimate is 0.41 log units below it; the measured number falls inside the stated range.
By their numbers in this assay, from the lowest: compounds 3 and 2 (each within the scatter of the next); then compounds 1 and 4 (each within the scatter of the next).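

Among these compounds, the step from the earlier compounds to this pair is the first that can be read at this position: on the double-bonded ring carbon, next to the ring atom that bears an aziridin-1-yl group, the same atoms of the carbamate side chain were joined differently, and in this assay this gives a number 0.27 log units higher from compound 1 to compound 4 (within the scatter). This assay therefore does not separate the two arrangements of the chain, and for this one pair the branching pattern of the side chain can be rearranged without a step that stands clear of the usual variation between repeats. No measurement shown here offers an explanation for this result, so it stands as an observation on a single pair.

The compounds shown leave open what would happen at this ring carbon if a hydroxyl group took the place of the carbamate, or if a longer chain carried it. They also leave open what the methyl group on the ring contributes, as no pair shown differs in that place alone.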